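A Carboxylic Acid in Place of the Ethylamide

The compounds below may be only part of what the source reports. "The series", "measured", "known", "first", "only" and "open" are said of these compounds alone.

Compound 1 `CCNC(=O)[C@H]1OC(n2cnc3c(NC)ncnc32)[C@H](O)[C@@H]1O` gives 120 nM in an assay with adenosine receptor A1 (Rattus norvegicus) as the target (on this read-out lower numbers stand for stronger inhibition and higher numbers for weaker inhibition), the higher of the two numbers shown. Compound 2 `CCNC(=O)[C@H]1OC(n2cnc3c(NC4CCCCC4)ncnc32)[C@H](O)[C@@H]1O` gives 1.7 nM in this assay, and the step of a 71-fold lower number from compound 1 to compound 2 (1.85 log units; beyond the scatter) is the only measured one. Compound 3 `CNc1ncnc2c1ncn2C1O[C@H](C(=O)O)[C@@H](O)[C@H]1O` differs from compound 1 by hydroxy in place of ethylamino on a carbonyl carbon. The measured step sits at another place, on a nitrogen on an aromatic ring, so it does not bear on this change and offers no guide to its size. For compound 3 a weaker result is expected, a step of a 33-fold higher number from compound 1 to compound 3 (1.52 log units; beyond the scatter), with an estimate of 4000 nM within a range of 500 nM to 40000 nM.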

Compound 3, half-maximal inhibitory concentration: 68 nM
Beside the measured number, compound 3's estimate is 59-fold (1.77 log units) above it, outside the stated range (below it).
By their numbers in this assay, from the lowest: compound 2; then compounds 3 and 1 (each within the scatter of the next).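

In this assay, hydroxy in place of ethylamino on a carbonyl carbon gives a 1.8-fold lower number from compound 1 to compound 3 (0.25 log units; within the scatter) and so leaves the read-out within the scatter. The earlier step concerned only the group on the nitrogen, whereas this one shows that, with methyl on that nitrogen, ethylamino is not required on the carbonyl carbon to keep the number of compound 1. No evidence at hand accounts for this result.

From the compounds shown here alone, it remains open whether the same change would read alike with cyclohexyl on the nitrogen, as in compound 2. Also open, going by these compounds, is how a primary amine or a longer alkyl chain on the amide nitrogen would read.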